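The source may report more compounds than this note shows. Statements on the series, on what has been measured and on what is new or still open speak of the compounds shown alone.

Values measured in a functional assay on Raji cells (Homo sapiens) for antiproliferative activity, read by MTT assay, with a stated time of 48 h; on this read-out higher numbers stand for weaker inhibition and lower numbers for stronger inhibition:
- compound 1 `CN(C)CCn1c(N)c(-c2nc3ccccc3[nH]2)c2nc(C#N)c(C#N)nc21`: 8320 nM
- compound 2 `CN1CCN(CCn2c(N)c(-c3nc4ccccc4[nH]3)c3nc(C#N)c(C#N)nc32)CC1`: > 50000 nM (a limit of the assay, not a number)
- compound 3 `CN(C)CCCn1c(N)c(-c2nc3ccccc3[nH]2)c2nc(C#N)c(C#N)nc21`: 1230 nM

Compound 3 is the strongest inhibitor of the three, and its value is the lower of the two true numbers. The next compound, compound 4 `CN(C)CCCn1c(N)c(-c2nc3ccccc3s2)c2nc(C#N)c(C#N)nc21`, keeps the 3-(dimethylamino)propyl group but has 1,3-benzothiazol-2-yl in place of 1H-benzimidazol-2-yl on an aromatic carbon.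

Among the measured compounds shown here, none of the measured steps touches this group. All three change the chain instead. Swapping dimethylamino for (dimethylamino)methyl gives a 6.8-fold lower number from compound 1 to compound 3 (0.83 log units; beyond the scatter). Bringing in 4-methylpiperazin-1-yl gives an at least 6.0-fold higher number from compound 1 to compound 2 (0.77 log units; beyond the scatter), and replacing it with (dimethylamino)methyl gives an at least 40-fold lower number from compound 2 to compound 3 (1.60 log units; beyond the scatter). These steps show that the series can respond strongly to a single change, but they say nothing about the direction of this new swap. The size of the chain steps therefore serves only as a rough guide to how wide the range should be. From the compounds shown here alone, compound 3 at 1230 nM is already the best value in the set, so a modest move toward weaker inhibition seems slightly more likely than a further gain, though either direction remains open. The expected change is a 2.0-fold higher number from compound 3 to compound 4 (0.31 log units; beyond the scatter), which is only an estimate. For compound 4 the estimated value in this assay is 2500 nM, with an expected range from 400 nM to 15000 nM.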

Compound 4, half-maximal inhibitory concentration: 2990 nM
Estimate against measurement, compound 4: 1.2-fold (0.08 log units) below; the measured number falls inside the stated range.
By their numbers in this assay, from the lowest: compound 3; then compound 4; then compound 1. At a limit, above all of these: compound 2.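

This is the first change shown at the group on the aromatic carbon rather than on the chain, and in this assay it gives a 2.4-fold higher number from compound 3 to compound 4 (0.39 log units; beyond the scatter). The position therefore responds to a swap between two groups with the same ring types: 1,3-benzothiazol-2-yl has sulfur where 1H-benzimidazol-2-yl has a nitrogen, and it has no hydrogen-bond donor where 1H-benzimidazol-2-yl has one, yet the step is only modest, much smaller than the largest step seen on the chain. The data shown offer no measured property that could explain this step.

The compounds shown cannot separate the loss of the hydrogen-bond donor from the arrival of sulfur, and a group such as 1-methyl-1H-benzimidazol-2-yl, which keeps both nitrogens but carries no such hydrogen, or 1,3-benzoxazol-2-yl, with oxygen in place of sulfur, would help to pull the two apart. From the compounds shown here alone, it also remains open whether the same swap gives a step of similar size on the shorter chain of compound 1.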